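The source may report more compounds than this note shows. Statements on the series, on what has been measured and on what is new or still open speak of the compounds shown alone.

Measured compounds:
compound 1 `O=C(NCCCCCCCCn1ccc2ccccc21)Oc1ccccc1` — 240 nM
compound 2 `Cc1cc(-c2ccccc2)c(-c2ccccc2)n1CCCCCCNC(=O)Oc1ccccc1` — 2600 nM
compound 3 `O=C(NCCCCCCCn1ccc2ccccc21)Oc1ccccc1` — 90 nM

In an assay on microsomes from brain (strain Sprague-Dawley) for inhibition of Fatty-acid amide hydrolase 1 (Rattus norvegicus), read by fluorescence and HPLC, with stated times of 10 min and 60 min (on this read-out lower numbers stand for stronger inhibition and higher numbers for weaker inhibition), compound 2 gives 2600 nM, the highest of the three numbers; compound 1 with 240 nM and compound 3 with 90 nM both lie well beyond the scatter below it. Compound 4 `COC(=O)c1c(-c2ccccc2)c(-c2ccccc2)n(CCCCCCNC(=O)Oc2ccccc2)c1C` differs from compound 2 only by the change (methoxycarbonyl in place of hydrogen on an aromatic carbon). Within the data shown here, no measured pair shows this change, so there is no step to lean on. The methoxycarbonyl enters a ring that already carries a methyl group and two phenyl groups, and no listed compound tells how such a crowded ring answers to one more group. The step from compound 2 to compound 4 is therefore expected to be small, a 1.2-fold higher number from compound 2 to compound 4 (0.06 log units; within the scatter), possibly within the scatter. Compound 4 is estimated at 3000 nM, in the range 1000 nM to 10000 nM.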

Compound 4, half-maximal inhibitory concentration: > 10000 nM
Compound 4 ended at the assay's limit (the forecaster's own chance of this, stated with the estimate: 10%); middle value at least 3.3-fold (0.52 log units) away from the limit.
By their numbers in this assay, from the lowest: compound 3; then compound 1; then compound 2. At a limit, above all of these: compound 4.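

The change gives an at least 3.8-fold higher number from compound 2 to compound 4 (0.58 log units; beyond the scatter), so in this assay this aromatic carbon, which bears hydrogen in compound 2, does not take methoxycarbonyl without a loss of inhibition. Compound 4 reads > 10000 nM, which is a limit of the assay and not a number: the limit of > 10000 nM in this assay, at which 1 of the 4 values shown sits.

The compounds shown leave open how far the step runs past that limit. They also leave open whether a carboxylic acid, an amide or a methyl group on the same carbon would give a number nearer that of compound 2.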